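A few compounds are considered here, and "the series" means these few. Any claim that something is new, unique, unknown or untested is made for them only; others in the source may bear on it.

Measured so far:

Compound 1, `COc1ccc(-c2cc(C(C)(C)C)cc(C(C)C)c2CO)cc1`, gives 1300 nM in a functional assay on RKE cells for antagonist activity at Vasoactive intestinal polypeptide receptor 1 (Rattus norvegicus), read by HTRF and cAMP accumulation, with stated times of 10 min and 30 min; on this read-out lower numbers stand for stronger inhibition and higher numbers for weaker inhibition.
Compound 2, `CC(C)c1cc(C(C)(C)C)cc(-c2ccc(Cl)cc2)c1CO`, gives 290 nM in this assay.
Compound 3, `COc1ccc(CCC(=O)Nc2sc3c(c2C#N)CCCC3)cc1`, gives 410 nM in this assay.

Compounds 1 and 2 share one core and differ in a single spot: chloro in place of methoxy on an aromatic carbon. That change brought a 4.5-fold lower number from compound 1 to compound 2 (0.65 log units; beyond the scatter), a move in the direction of stronger inhibition.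

Compound 3 is built on a different core; how the two cores differ is not broken down here. Compound 4, `N#Cc1c(NC(=O)CCc2ccc(Cl)cc2)sc2c1CCCC2`, has not yet been measured. Compared with compound 3 it carries the same kind of change seen between compound 1 and compound 2: chloro in place of methoxy on an aromatic carbon. Around the place the description adds that, cut one bond further out, the change reads 4-methoxyphenyl to 4-chlorophenyl, so the setting is a similar but not identical one.

Because the earlier step of a 4.5-fold lower number from compound 1 to compound 2 (0.65 log units; beyond the scatter) went clearly in one direction, compound 4 is expected to show a lower number than compound 3, although on a new core the size of the move is uncertain and may be smaller. The estimated step is a 2.7-fold lower number from compound 3 to compound 4 (0.44 log units; beyond the scatter). Compound 4 is expected to give about 150 nM in this assay, with a likely range from 50 nM to 400 nM.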

Compound 4, half-maximal inhibitory concentration: 1200 nM
Compound 4: the middle estimate sits 8.0-fold (0.90 log units) below what was measured; measured number above the stated range.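

On the core of compound 3, the change from methoxy to chloro runs the opposite way to what it did on the core of compound 1: in this assay it produced a 2.9-fold higher number from compound 3 to compound 4 (0.47 log units; beyond the scatter) and so points toward weaker inhibition. This shows that the result of this swap cannot simply be carried from one core to the other in this series, since the two steps disagree in direction and the gap between them is larger than repeated measurements would explain: the same change on two cores in this assay, a 4.5-fold lower number (0.65 log units; beyond the scatter) from compound 1 to compound 2 and a 2.9-fold higher number (0.47 log units; beyond the scatter) from compound 3 to compound 4, 13-fold (1.12 log units) apart, beyond the scatter of two such steps. Among these compounds, it does not show why the two cores respond differently, and with only two cores on record, neither can be called the typical case nor can the response of a third core be foretold.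

The compounds shown carry only methoxy or chloro at this place on the six-membered aromatic ring, so it remains open whether a hydrogen, a fluoro or a methyl group there would follow the pattern of compounds 1 and 2 or that of compounds 3 and 4. From the compounds shown here alone, it also remains open whether the opposite trend would hold if an amine or a carboxylic acid stood at this place on both cores.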